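The source may report more compounds than this note shows. Statements on the series, on what has been measured and on what is new or still open speak of the compounds shown alone.

Measured compounds in a functional assay on COLO 205 cells (Homo sapiens) for cytotoxicity, read by MTT assay, with a stated time of 72 h; a lower number here means a stronger inhibitor, a higher number a weaker inhibitor:
compound 1 `COc1ccc(C(=O)c2cc(OC)c(OC)c(OC)c2)cc1NC(=O)/C=C/c1cc(OC)c(OC)c(OC)c1` gives 5200 nM;
compound 2 `COc1ccc(C(=O)c2cc(OC)c(OC)c(OC)c2)cc1NC(=O)/C=C/c1ccc(OC)c(OC)c1` gives 8200 nM;
compound 3 `COc1ccc(C(=O)c2cc(OC)c(OC)c(OC)c2)cc1NC(=O)/C=C/c1ccc(C(F)(F)F)cc1` gives 2600 nM.

Compound 3 carries the lowest of the three numbers in this assay. The two steps that lead to it are a 2.0-fold lower number from compound 1 to compound 3 (0.30 log units; within the scatter) and a 3.2-fold lower number from compound 2 to compound 3 (0.50 log units; beyond the scatter). Only the second of these is beyond the scatter, so compound 3 is separated from compound 2 but not from compound 1.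

Compound 4 `COc1ccc(C(=O)c2cc(OC)c(OC)c(OC)c2)cc1NC(=O)/C=C/c1ccc(N)cc1` changes the ring on the ethenyl chain once more: amino in place of trifluoromethyl on an aromatic carbon. Among the compounds with values here, the steps that bear on this are those in which the same ring was exchanged, from compound 1 to compound 3 and from compound 2 to compound 3. Both replaced a methoxy-bearing ring with the 4-(trifluoromethyl)phenyl and moved the number modestly at most. Within the data shown here, no measured step brings an amino onto this ring, so the direction is open; the size is expected to stay modest, a step of a 1.7-fold higher number from compound 3 to compound 4 (0.24 log units; within the scatter), toward a somewhat higher number. Compound 4 is therefore estimated at 4500 nM, within 1800 nM to 11000 nM.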

Compound 4, half-maximal inhibitory concentration: 10300 nM
For compound 4 the middle estimate is 2.3-fold (0.36 log units) below the measured one, and the stated range covers the measured number.
By their numbers in this assay, from the lowest: compounds 3, 1, 2 and 4 (each within the scatter of the next, the first and the last beyond it).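

In this assay, the ring on the ethenyl chain now shows a change of a single group, with amino in place of trifluoromethyl para to a large group (a 4.0-fold higher number from compound 3 to compound 4 (0.60 log units; beyond the scatter)), and this step lies beyond the scatter. The 4-aminophenyl does not separate from the methoxy-bearing rings (a 1.3-fold higher number from compound 2 to compound 4 (0.10 log units; within the scatter); a 2.0-fold higher number from compound 1 to compound 4 (0.30 log units; within the scatter)), so among these four compounds only the 4-(trifluoromethyl)phenyl stands apart from any other ring, and then from compounds 2 and 4 but not from compound 1. No measurement is available that accounts for this step.

From the compounds shown here alone, whether a nitrile, a carboxylic acid or a methyl at this place would stay with compound 3 or fall with compound 4 remains open. Also open, going by these compounds, is whether an acetylated amine would keep the number of compound 4.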